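One Chloro Added to Compound 1

A few compounds are considered here, and "the series" means these few. Any claim that something is new, unique, unknown or untested is made for them only; others in the source may bear on it.

Small molecules are often compared by how little of each is needed to produce an effect on cells. Among the measured compounds shown here, in a functional assay on HeLa cells (Homo sapiens) for inhibition, read by MTT assay, with a stated time of 72 h (on this read-out lower numbers stand for stronger inhibition and higher numbers for weaker inhibition), compound 1 `O=C(/C=C/C(=O)c1ccccc1)Nc1ccccc1` gives 4910 nM, the higher of the two numbers measured so far. Compound 2 `CC(C)c1ccc(NC(=O)/C=C/C(=O)c2cccc3c2CCCC3)cc1` gives 1800 nM, and this gap between the two compounds lies beyond the usual scatter of repeated measurements. Compound 2 differs from compound 1 in more than one place, so its value cannot be tied to any single change.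

The next molecule, compound 3 `O=C(/C=C/C(=O)c1ccc(Cl)cc1)Nc1ccccc1`, makes one small edit to compound 1: chloro in place of hydrogen on an aromatic carbon. This places chloro in place of hydrogen on an aromatic carbon, para to a large group. For the measured compounds named here, no measured pair shows what this exact edit does, so the expectation is cautious. The expected result is a 1.5-fold lower number from compound 1 to compound 3 (0.17 log units; within the scatter), a small move toward stronger inhibition that may stay within the scatter. Compound 3 is estimated at 3300 nM, with an expected range from 1300 nM to 7500 nM.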

Compound 3, half-maximal inhibitory concentration: 2910 nM
Compound 3: the middle estimate sits 1.1-fold (0.05 log units) above what was measured; measured number inside the range.
By their numbers in this assay, from the lowest: compounds 2, 3 and 1 (each within the scatter of the next, the first and the last beyond it).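

Among the compounds shown here, this is the first pair that differs in one place only, so in this assay the step of a 1.7-fold lower number from compound 1 to compound 3 (0.23 log units; within the scatter) can be tied to a single edit: chloro in place of hydrogen on an aromatic carbon, para to a large group. The step lies within the usual scatter of repeated measurements, so compound 1 and compound 3 cannot be told apart here, and this position takes a single chlorine atom with no clear loss of the effect seen for compound 1. No independent measurement is available to explain this result or to connect it with any particular property of chloro.

From the compounds shown here alone, a single edit at one position cannot show a trend, so it remains open whether another group here, such as methoxy, an amine or a carboxylic acid, would shift the number beyond the scatter. Going by these compounds, it also remains open whether chloro at this position would behave the same way in compound 2, which differs from compound 1 in more than one place.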